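Aryl in place of cyclohexyl at the ring carbon

The compounds below may be only part of what the source reports. "The series", "measured", "known", "first", "only" and "open" are said of these compounds alone.

Going by the values given here, compound 2 `COc1nc(C2CCCCC2)ccc1[C@@H](c1ccccc1)[C@@](O)(CCN(C)C)c1cccc2ccccc12` gives the only number in a toxicity assay on Vero cells (Chlorocebus sabaeus) for cytotoxicity (on this read-out lower numbers stand for higher toxicity in this test and higher numbers for lower toxicity in this test), 32.3 ug/mL. Compound 1 `COc1nc(-c2cccc(Cl)c2)ccc1[C@@H](c1ccccc1)[C@@](O)(CCN(C)C)c1cccc2ccccc12` sits at a limit of this assay, > 50 ug/mL. Among the compounds with values here, the single measured step, an at least 1.5-fold lower number from compound 1 to compound 2 (0.18 log units; that floor lies within the scatter), is the one that bears on compound 3 `COc1nc(-c2ccc(Br)cc2)ccc1[C@@H](c1ccccc1)[C@@](O)(CCN(C)C)c1cccc2ccccc12`, where the change runs the other way: 4-bromophenyl in place of cyclohexyl on an aromatic carbon. With one of the two values at the limit of > 50 ug/mL in this assay, at which 1 of the 2 values shown sits, the expectation is a modest rise that may again reach a limit, a 1.4-fold higher number from compound 2 to compound 3 (0.14 log units; within the scatter). Compound 3 is therefore estimated at 45 ug/mL, with a range from 25 ug/mL to 80 ug/mL.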

Compound 3, half-maximal cytotoxic concentration: > 50 ug/mL
Compound 3: a limit, no number; the forecaster's own chance of this, stated with the estimate: 45%; at least 1.1-fold (0.04 log units) between middle value and limit.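

In this assay, a second aryl group at this ring carbon gives the same kind of result as the first, with 4-bromophenyl in place of cyclohexyl giving an at least 1.5-fold higher number from compound 2 to compound 3 (0.18 log units; that floor lies within the scatter). Even so, neither step involving cyclohexyl is shown to exceed the scatter, and compound 2 remains the only compound with a number. The step between compound 1 and compound 3 cannot be read, since each value is a limit: the limit of > 50 ug/mL in this assay, at which 2 of the 3 values shown sit.

Going by these compounds, how far the values of compound 1 and compound 3 lie past that limit stays open. So does the reading in this assay for an amine or a carboxylic acid at this ring carbon.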